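The source may hold more compounds than are shown below. What is called first, only, known or untested is meant among the compounds shown, and "the series" means these compounds.

Working notes on the series.

The set shares one core, seen in compound 1, `N/C(=N\C(=O)CC(c1ccccc1)c1ccccc1)NCCCc1ccccc1`, where a phenyl sits on the saturated chain carbon three bonds from the amine nitrogen. In a functional assay on Sf9 cells for antagonist activity at histamine H2 receptor (Homo sapiens), with stated times of 2 min and 20 min (on this read-out lower numbers stand for lower potency and higher numbers for higher potency (the scale is a negative logarithm)), compound 1 gives 5.89. Compound 2, `CN(C)Cc1ccc(CCCN/C(N)=N/C(=O)CC(c2ccccc2)c2ccccc2)o1`, carries the furan bearing the dimethylaminomethyl group in that place; in this assay compound 2 gives 7.03, and the step of a number 1.14 log units higher from compound 1 to compound 2 (beyond the scatter) is the only large one seen. Compound 3, `N/C(=N\C(=O)CC(c1ccccc1)c1ccccc1)NCCCc1ncc[nH]1`, carries the imidazolyl in the same place and in this assay compound 3 gives 6.13. It stands second of the three numbers; the step of a number 0.24 log units higher from compound 1 to compound 3 (within the scatter) is within the scatter, while the step of a number 0.90 log units lower from compound 2 to compound 3 (beyond the scatter) is beyond it.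

Compound 4, `N/C(=N\C(=O)CC(c1ccccc1)c1ccccc1)NCCCc1cn[nH]c1`, differs from compound 3 by 1H-pyrazol-4-yl in place of 1H-imidazol-2-yl on a saturated chain carbon, three bonds along the chain from an amine nitrogen. Among the measured compounds shown here, no measured step exchanges one five-membered ring with two nitrogens for its isomer; the two steps that bear on compound 3 show only that a phenyl and an imidazolyl in that place read the same within the scatter, and that the furan derivative reads higher. With nothing that speaks for a change, the expectation for compound 4 is a step of a number 0.03 log units lower from compound 3 to compound 4 (within the scatter), so within the scatter. Compound 4 is therefore estimated at 6.1 in this assay, with a range from 5.5 to 6.7.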

Compound 4, negative logarithm of the antagonist equilibrium constant: 5.42
For compound 4 the middle estimate is 0.68 log units above the measured one; measured number outside the range, below it.
By their numbers in this assay, from the lowest: compound 4; then compounds 1 and 3 (each within the scatter of the next); then compound 2.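

In this assay, the place on a saturated chain carbon, three bonds along the chain from an amine nitrogen, separates two rings with the same atoms and the same donor and acceptor counts: the change to 1H-pyrazol-4-yl gives a number 0.71 log units lower from compound 3 to compound 4 (beyond the scatter), so how the ring is joined matters here and not only what it contains. The same ring also gives a number 0.47 log units lower from compound 1 to compound 4 (beyond the scatter), the first replacement in the series to fall beyond the scatter under the phenyl of compound 1, so a five-membered aromatic ring with 2 hetero atoms does not by itself keep the reading of the phenyl. The range at this position widens as well, with a number 1.61 log units lower from compound 2 to compound 4 (beyond the scatter), and the 5-((dimethylamino)methyl)furan-2-yl group stays beyond the scatter above the other three groups.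

No measurement shown accounts for the gap between the two isomeric rings. Still open, from the compounds shown here alone, is whether a longer chain than the propyl, or a dimethylaminomethyl group carried on the 1H-pyrazol-4-yl ring, would move the reading of compound 4.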